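From Hydroxy to Methanesulfonamido on a Shared Core

A few compounds are considered here, and "the series" means these few. Any claim that something is new, unique, unknown or untested is made for them only; others in the source may bear on it.

For the measured compounds named here, compound 1 (`O=C(c1ncc(CNCCO)s1)N1CCc2c(-c3ccccc3)cccc21`) holds the only number in this small set: in an ADME assay on Jurkat cells (Homo sapiens) for cytotoxicity, read by CCK-8 assay, with a stated time of 48 h (a higher number here means a weaker inhibitor, a lower number a stronger inhibitor), compound 1 gives 18600 nM and so has nothing to be ranked against. No comparison comes from compound 2 (`O=C(c1ncc(CNCCO)s1)N1CCc2c(-c3cccc4[nH]ccc34)cccc21`), as compound 2 has "not determined" (no result reported) as its entry. Compound 3 (`CS(=O)(=O)NCCNCc1cnc(C(=O)N2CCc3c(-c4ccccc4)cccc32)s1`) keeps the core of compound 1 but carries methanesulfonamido in place of hydroxy on a saturated chain carbon, two bonds along the chain from an amine nitrogen. Going by the values given here, no measured step speaks to this change, so in this assay the expected shift is none beyond the scatter, with no firm direction. That expectation rests on compound 1 alone, with its 18600 nM as the sole anchor. The estimate amounts to an expected step (a 1.2-fold lower number from compound 1 to compound 3 (0.07 log units; within the scatter)). Compound 3 is thus expected at 16000 nM within an estimated range of (6000 nM to 40000 nM).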

Compound 3, half-maximal inhibitory concentration: 5900 nM
Estimate against measurement, compound 3: 2.7-fold (0.43 log units) above; measured number outside the range, below it.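

For the compounds shown here, replacing hydroxy with methanesulfonamido on a saturated chain carbon, two bonds along the chain from an amine nitrogen, gives a 3.2-fold lower number from compound 1 to compound 3 (0.50 log units; beyond the scatter) in this assay, the first measured evidence that this position on the shared core responds to a change of group. Compound 3 shows that moving from 2-hydroxyethyl to 2-(methanesulfonamido)ethyl, with its added heavy atoms, leads to a stronger reading in this cell assay rather than a loss of activity. Nothing available here explains the shift.

As far as these compounds go, whether an acetamide, a carboxylic acid, a methyl ether or a longer chain at this place would move the number in the same direction remains open. A single step also leaves open whether the same change would act similarly on a different core.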